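Bromo to Chloro on the Aniline Ring of Sulfonamides

A few compounds are considered here, and "the series" means these few. Any claim that something is new, unique, unknown or untested is made for them only; others in the source may bear on it.

Compound 1 `O=C1CCCCC1S(=O)(=O)Nc1ccccc1Br`: -14.4%
Compound 2 `O=C1CCCCC1S(=O)(=O)Nc1ccc(Cl)cc1`: -3.83%
Compound 3 `O=C1CCCCC1S(=O)(=O)Nc1cc(C(F)(F)F)cc(C(F)(F)F)c1`: 76%

Of the compounds shown here, three sharing a core have been tested in a functional assay on KB cells (Homo sapiens) for antiproliferative activity, read by sulforhodamine B assay, tested at 100 ug/mL; a lower number here means less inhibition, a higher number more inhibition at the concentration tested (going by the name of the read-out). Compound 1 stands lowest of the three; its nearest neighbour is compound 2, whose number lies higher by a margin beyond the scatter, and the furthest is compound 3, whose number lies far higher, well beyond the scatter. In this assay compound 3 gives 76%, while compound 2 gives -3.83% and compound 1 gives -14.4%.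

The next compound, compound 4 `O=C1CCCCC1S(=O)(=O)Nc1ccccc1Cl`, differs from compound 1 in one place: chloro in place of bromo on an aromatic carbon. Going by the values given here, no step between two measured compounds follows this exact change, so its size is not known. Compound 2 also carries a chloro group and sits within a modest distance of compound 1, which suggests that a halogen swap of this kind does not move the number far. The step from compound 1 to compound 4 is therefore expected to be small, at most a slight rise, and likely within the scatter: a number 8.4 percentage points higher from compound 1 to compound 4 (within the scatter). Compound 4 is expected to give about -6%, with a likely range from -25% to 18%.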

Compound 4, a percentage reported as inhibition, at one concentration (the size of the read-out at that concentration, not a potency): -10.1%
Estimate against measurement, compound 4: 4.1 percentage points above; the measured number falls inside the stated range.
By their numbers in this assay, from the lowest: compounds 1, 4 and 2 (each within the scatter of the next, the first and the last beyond it); then compound 3.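

In this assay, chloro in place of bromo on an aromatic carbon, ortho to a large group, gives a number 4.3 percentage points higher from compound 1 to compound 4 (within the scatter). Going by these compounds alone, this is the first pair that differs in one place only, so the earlier compounds could only hint at what this swap does, whereas here it is read directly. At this position, the read-out does not tell the bromo compound from the chloro compound, and the swap therefore gives no measurable change at the concentration tested. No measurement shown here accounts for this result.

What the compounds leave open is whether a different kind of group on this same aromatic carbon, such as an amine, a carboxylic acid or a methoxy group, would move the number beyond the scatter, or whether it would stay as close as chloro and bromo do. On these data alone, it also remains open whether chloro in place of bromo would give so small a step on another carbon of the ring, since this single step speaks only for the position it was read at.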